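Fluorophenyl isomers: from compound 3 to compound 4

The compounds below may be only part of what the source reports. "The series", "measured", "known", "first", "only" and "open" are said of these compounds alone.

In a functional assay on HL-60 cells (Homo sapiens) for cytotoxicity, read by MTT assay, with a stated time of 48 h (a lower number here means a stronger inhibitor, a higher number a weaker inhibitor), compound 3 (`COc1cc2c(=O)cc(-c3ccccc3F)[nH]c2cc1O`) gives 1300 nM, level with compound 1 (`COc1ccc2[nH]c(-c3cccc(F)c3)cc(=O)c2c1OC`) at 1300 nM. These two share the highest number of the three measured. Compound 2 (`O=c1cc(-c2ccccc2F)[nH]c2ccc(O)c(O)c12`) gives 500 nM, a lower number beyond the usual scatter, which leaves compound 3 on the weaker side of this small set.

Compound 4 (`COc1cc2c(=O)cc(-c3ccc(F)cc3)[nH]c2cc1O`), not yet measured, carries 4-fluorophenyl in place of 2-fluorophenyl on an aromatic carbon. The place of exchange lies next to the ring nitrogen. Among the compounds with values here, no two measured compounds differ in one place only, so the data give no direct size for such a change. The only indirect hint comes from compound 1, which has a different fluorophenyl group and a different substitution on the core, yet gives 1300 nM, the same digits as compound 3 at 1300 nM.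

In this assay no change beyond the scatter is expected, in either direction. The estimated step is a 1.1-fold lower number from compound 3 to compound 4 (0.03 log units; within the scatter). For compound 4 the expected value is 1200 nM, with an estimated range from 450 nM to 3500 nM.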

Compound 4, half-maximal inhibitory concentration: 38200 nM
For compound 4 the middle estimate is 32-fold (1.50 log units) below the measured one; measured number above the stated range.
By their numbers in this assay, from the lowest: compound 2; then compounds 1 and 3 (each within the scatter of the next); then compound 4.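

Working notes on the fluorophenyl position: in this assay, the exchange of 2-fluorophenyl for 4-fluorophenyl gives a 29-fold higher number from compound 3 to compound 4 (1.47 log units; beyond the scatter), the first step in this series that can be read at a single place. The entering and leaving groups have the same heavy-atom count and the same atoms, so this large step separates two isomers and cannot be tied to any gain or loss of atoms. The aromatic carbon next to the ring nitrogen is therefore a place where the result in this cytotoxicity read-out depends strongly on how the fluorophenyl group is substituted, and the data at hand offer no explanation for the size of the step.

Open, going by these compounds, is how far this dependence extends on the shared core of compound 3 and compound 4: whether 3-fluorophenyl, unsubstituted phenyl or 2-chlorophenyl at this carbon would stay close to compound 3 or fall toward compound 4. Also open, on these data alone, is whether 2-methoxyphenyl or 4-methoxyphenyl would show a step of similar size, and whether the same exchange would give a comparable step on a differently substituted core.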